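Working notes: dropping the methylsulfonyl group from compound 2

This account rests on a few compounds, and the source may have more. Where it says the series, first, only, none or still open, it means among the compounds named here.

Measured in an ADME assay on microsomes from liver (Homo sapiens) for metabolic stability; on this read-out higher numbers stand for a longer-lived compound and lower numbers for a shorter-lived compound:
- compound 1 `COc1cc(OCc2csc(-c3ccc(C(C)(C)O)cc3)n2)c2cc(-c3cn4nc(OC)sc4n3)oc2c1`: 1.83 h
- compound 2 `COc1cc(OCc2csc(-c3ccc(S(C)(=O)=O)cc3)n2)c2cc(-c3cn4nc(OC)sc4n3)oc2c1`: 1.22 h

Compound 2 and compound 1, the only two measured so far, lie within the scatter of each other. Compound 3 `COc1cc(OCc2csc(-c3ccccc3)n2)c2cc(-c3cn4nc(OC)sc4n3)oc2c1` is the next to be read. The change is hydrogen in place of methylsulfonyl on an aromatic carbon, so that 4-(methylsulfonyl)phenyl becomes phenyl. Going by the values given here, one measured step bears on this place, a 1.5-fold lower number from compound 1 to compound 2 (0.18 log units; within the scatter), where methylsulfonyl replaced 1-hydroxy-1-methylethyl. Among the compounds with values here, that step exchanged one group for another, and no measured compound yet shows this position carrying hydrogen, so the evidence is indirect. Within the data shown here, with only that small step to go on, no change beyond the scatter is expected in this assay. The expected step is a 1.1-fold higher number from compound 2 to compound 3 (0.06 log units; within the scatter). For compound 3 the estimated half-life is 1.4 h, with an expected range of 0.7 h to 2.6 h.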

Compound 3, half-life: 1.33 h
For compound 3 the middle estimate is 1.1-fold (0.02 log units) above the measured one, and the stated range covers the measured number.
By their numbers in this assay, from the lowest: compounds 2, 3 and 1 (each within the scatter of the next).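

In this assay, going by these compounds alone, compound 3 gives the first direct reading of this position carrying hydrogen, where the earlier comparison only exchanged one group for another. Loss of methylsulfonyl gives a 1.1-fold higher number from compound 2 to compound 3 (0.04 log units; within the scatter), and replacing 1-hydroxy-1-methylethyl with hydrogen gives a 1.4-fold lower number from compound 1 to compound 3 (0.14 log units; within the scatter), so hydrogen, methylsulfonyl and 1-hydroxy-1-methylethyl at this position all give half-lives within the scatter of one another. No supporting measurement accounts for this lack of separation.

Still open, on these data alone, is whether an amine, a carboxylic acid or a longer chain at this position would give a step beyond the scatter. These three compounds share the same core, so they leave open whether the same lack of separation would hold on a different core.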